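Pyridylpiperazine in place of pyrrolidine on compound 3

The compounds below may be only part of what the source reports. "The series", "measured", "known", "first", "only" and "open" are said of these compounds alone.

The series shares a core carrying a urea and a (1H-indol-3-yl)sulfanyl group. In a functional assay on MDA-MB-231 cells (Homo sapiens) for inhibition, with a stated time of 72 h (on this read-out lower numbers stand for stronger inhibition and higher numbers for weaker inhibition), compound 1 `Cc1cc(Cl)ccc1NC(=O)Nc1nc(Sc2c[nH]c3ccccc23)cc(N2CCN(Cc3ccccc3)CC2)n1` gives 22100 nM, compound 2 `Cc1cc(Cl)ccc1NC(=O)Nc1nc(Nc2ccccc2)cc(Sc2c[nH]c3ccccc23)n1` gives 17100 nM and compound 3 `Cc1cc(Cl)ccc1NC(=O)Nc1nc(Sc2c[nH]c3ccccc23)cc(N2CCCC2)n1` gives 9440 nM. Compound 3 has the lowest number of the three; against compound 2 the gap is within the scatter, against compound 1 it lies beyond it. For the measured compounds named here, the only single-point step measured, a 1.8-fold lower number from compound 2 to compound 3 (0.26 log units; within the scatter), stays within the scatter.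

Compound 4 `Cc1cc(Cl)ccc1NC(=O)Nc1nc(Sc2c[nH]c3ccccc23)cc(N2CCN(c3ccccn3)CC2)n1` differs from compound 3 in one place: 4-(pyridin-2-yl)piperazin-1-yl in place of pyrrolidin-1-yl on an aromatic carbon. Going by the values given here, no measured step covers this exact change. The nearest comparison is compound 1, which carries a benzyl-substituted piperazine at the same aromatic carbon and shows a higher number than compound 3, the two values differing beyond the scatter. Compound 4 is therefore expected to move toward the weaker end, with a step of a 1.9-fold higher number from compound 3 to compound 4 (0.28 log units; within the scatter). The estimate for compound 4 in this assay is 18000 nM, within a range from 7000 nM to 45000 nM.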

Compound 4, half-maximal inhibitory concentration: 34700 nM
Estimate against measurement, compound 4: 1.9-fold (0.29 log units) below; measured number inside the range.
By their numbers in this assay, from the lowest: compounds 3, 2, 1 and 4 (each within the scatter of the next, the first and the last beyond it).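

Working from this assay, 4-(pyridin-2-yl)piperazin-1-yl in place of pyrrolidin-1-yl gives a 3.7-fold higher number from compound 3 to compound 4 (0.57 log units; beyond the scatter) at this carbon next to the ring nitrogen, the first single-place step on the core that clears the scatter. The same group in place of anilino gives a 2.0-fold higher number from compound 2 to compound 4 (0.31 log units; beyond the scatter) and so also clears it, which puts compound 4 on the weaker side of both compounds with the smaller substituents at this carbon. On the piperazine nitrogen, pyridin-2-yl in place of benzyl gives a 1.6-fold higher number from compound 1 to compound 4 (0.20 log units; within the scatter) and does not separate the two substituted piperazines, and no supporting data bear on the reason for any of these steps.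

Still open, going by these compounds, is whether the higher numbers follow from the piperazine ring itself or from its aryl and benzyl substituents. An unsubstituted piperazine or a morpholine at this carbon would separate those two readings.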